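A Quiet Cytotoxicity Series: Oxazole Replaces Sulfonamide

A few compounds are considered here, and "the series" means these few. Any claim that something is new, unique, unknown or untested is made for them only; others in the source may bear on it.

Measured compounds:
Compound 1, `CS(=O)(=O)Nc1cccc(C(=O)N2CCCC(C(=O)Nc3ccc(Cl)cc3)C2)c1`: 3%
Compound 2, `O=C(Nc1cccc(Cc2ccccc2)c1)C1CCCN(C(=O)c2cccc(-c3ccco3)c2)C1`: 0%
Compound 3, `O=C(c1ccccc1)c1cccc(NC(=O)C2CCCN(C(=O)c3cc(C(F)(F)F)cc(C(F)(F)F)c3)C2)c1`: 0%

In an ADME assay on PC-3 cells (Homo sapiens) for cytotoxicity, read by WST assay, tested at 100 uM (on this read-out higher numbers stand for more inhibition at the one concentration tested (going by the name of the read-out) and lower numbers for less inhibition), compound 1 gives 3%. Compound 2 and compound 3 give numbers that differ from compound 1 by gaps within the scatter, so compound 1 stands together with both, none of the three set apart from the others. All three share a core and show little inhibition at the single concentration tested.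

Compound 4, `O=C(Nc1ccc(Cl)cc1)C1CCCN(C(=O)c2cccc(-c3cnco3)c2)C1`, differs from compound 1 in one place: 1,3-oxazol-5-yl in place of methanesulfonamido on an aromatic carbon. Going by the values given here, no measured pair isolates such a change, so no step of known size is available; the three shared-core compounds sitting together in this assay point to no step beyond the scatter in either direction.

Compound 4 is therefore expected to give 3% in this assay, with a range from -6% to 13%, meaning an expected step of no change at the digits printed from compound 1 to compound 4 (within the scatter).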

Compound 4, a percentage reported as inhibition, at one concentration (the size of the read-out at that concentration, not a potency): 0%
Compound 4: middle estimate off by 3 percentage points, on the high side; the range from low to high includes it.
By their numbers in this assay, from the lowest: compounds 2, 3, 4 and 1 (each within the scatter of the next).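

In this assay, going by these compounds alone, placing 1,3-oxazol-5-yl in place of methanesulfonamido on this aromatic carbon gives a number 3 percentage points lower from compound 1 to compound 4 (within the scatter) and is the first single-place change that can be read. The exchange removes the hydrogen-bond donor of the leaving group and brings in a five-membered aromatic ring, yet the read-out shows no change beyond the scatter. From the compounds shown here alone, whether an amine or a carboxylic acid on this carbon would lift the number beyond the scatter remains open. No measured evidence on either group bears on this result.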